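The source may hold more compounds than are shown below. What is called first, only, known or untested is meant among the compounds shown, and "the series" means these compounds.

Measured compounds in a functional assay on the whole organism (strain albino) for inhibition, with Rattus norvegicus as the target, read by paw edema, with a stated time of 1 h, at a dose of 100 mg/kg by the oral route; on this read-out lower numbers stand for less inhibition and higher numbers for more inhibition at the one dose given (going by the name of the read-out):
- compound 1 `N#Cc1c(Nc2ccccc2)nc(SCC(=O)Nn2c(COc3ccc(Cl)cc3Cl)nc3ccccc3c2=O)nc1-c1ccccc1`: 77.3%
- compound 2 `N#Cc1c(Nc2ccc(Cl)cc2)nc(SCC(=O)Nn2c(COc3ccc(Cl)cc3Cl)nc3ccccc3c2=O)nc1-c1ccccc1`: 54.6%
- compound 3 `N#Cc1c(Nc2ccc(O)cc2)nc(SCC(=O)Nn2c(COc3ccc(Cl)cc3Cl)nc3ccccc3c2=O)nc1-c1ccccc1`: 72.7%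

Compound 3 stands second highest of the three numbers. It sits within the scatter of compound 1, the step being a number 4.6 percentage points lower from compound 1 to compound 3 (within the scatter), and beyond the scatter above compound 2, with a number 18.1 percentage points higher from compound 2 to compound 3 (beyond the scatter). No order between compound 3 and compound 1 can be claimed.

Compound 4 `N#Cc1c(Nc2ccc(O)cc2)nc(SCC(=O)Nn2c(COc3ccc(Cl)cc3Cl)nc3ccccc3c2=O)nc1-c1ccc(Cl)cc1` differs from compound 3 by chloro in place of hydrogen on an aromatic carbon, on the phenyl of the shared core rather than on the ring that carries hydroxy.

Among the measured compounds shown here, the one measured step of the same kind, chloro in place of hydrogen on an aromatic carbon, is a number 22.7 percentage points lower from compound 1 to compound 2 (beyond the scatter), though that chloro entered a different ring. A step of similar direction but uncertain size is therefore expected in this assay, a drop that may or may not clear the scatter.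

Compound 4 is estimated at 62%, in the range 46% to 76%, which means an expected step of a number 10.7 percentage points lower from compound 3 to compound 4 (beyond the scatter).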

Compound 4, a percentage reported as inhibition, in the whole organism at one dose (the size of the read-out at that dose, not a potency): 90.9%
The estimate for compound 4 lay 28.9 percentage points below the measured number; the whole stated range lies below it.
By their numbers in this assay, from the lowest: compound 2; then compounds 3 and 1 (each within the scatter of the next); then compound 4.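

In this assay, chloro in place of hydrogen on an aromatic carbon para to a large group, here on the phenyl of the shared core, gives a number 18.2 percentage points higher from compound 3 to compound 4 (beyond the scatter). Among the compounds shown here, this exchange can therefore go with more inhibition at the one dose given, which the earlier compounds did not show: their only chloro step, on the ring bearing the amino link, gave a number 22.7 percentage points lower from compound 1 to compound 2 (beyond the scatter). The direction of the exchange thus differs with the ring and compound pair, so chloro in place of hydrogen cannot be read as one effect across this series: the same change on two cores in this assay, a number 22.7 percentage points lower (beyond the scatter) from compound 1 to compound 2 and a number 18.2 percentage points higher (beyond the scatter) from compound 3 to compound 4, 40.9 percentage points apart, beyond the scatter of two such steps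

The exchange on this phenyl is shown only with hydroxy on the other ring, so whether the rise also occurs without that hydroxy remains open. Also open, as far as these compounds go, is whether an amine or a methoxy group at this same place would follow chloro.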